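A few compounds are considered here, and "the series" means these few. Any claim that something is new, unique, unknown or untested is made for them only; others in the source may bear on it.

Measured so far in an ADME assay on BJ cells (Homo sapiens) for cytotoxicity, read by luminescence, with a stated time of 72 h; on this read-out higher numbers stand for an effect only at larger amounts of compound and lower numbers for an effect already at smaller amounts:
compound 1 `CCOC(=O)c1c(-c2cccc(OC(C)C)c2)[nH]c2cc(OC)ccc2c1=O`: > 21500 nM, a limit of the assay
compound 2 `CCOC(=O)c1c(-c2cccc(OCC(C)C)c2)[nH]c2cc(OC)ccc2c1=O`: > 21500 nM, a limit of the assay
compound 3 `CCOC(=O)c1c(-c2cccc(C(C)=O)c2)[nH]c2cc(OC)ccc2c1=O`: > 21500 nM, a limit of the assay

Compound 1 stands at the limit of this assay, without a number of its own, and the two further values shown sit at the same limit (the limit of > 21500 nM in this assay, at which 3 of the 3 values shown sit). Nothing in these values sets compound 1 apart from compound 2 or compound 3.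

Compound 4 `CCOC(=O)c1c(-c2cccc(NC(C)=O)c2)[nH]c2cc(OC)ccc2c1=O` differs from compound 1 in one place: acetamido in place of isopropoxy on an aromatic carbon. The group enters on the aromatic carbon meta to a large group, where compound 1 carries isopropoxy.

The measured steps that touch this place are a step that the two limits leave unreadable from compound 1 to compound 3 and a step that the two limits leave unreadable from compound 2 to compound 3, both exchanging an alkoxy group for acetyl, and neither gives a readable size, since both ends rest at the limit. The step that the two limits leave unreadable from compound 1 to compound 2 is unreadable in the same way. Within the data shown here, no step has been read, so no direction can be taken from it, and no change beyond the scatter is expected in this assay.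

Compound 4 is therefore expected to come out at 25000 nM, within 12000 nM to 60000 nM, most likely reported again only as a limit. The expected step is a step that the limit leaves unreadable from compound 1 to compound 4.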

Compound 4, half-maximal effective concentration: > 21500 nM
Compound 4 ended at the assay's limit; the forecaster's own chance of this, stated with the estimate: 85%; the middle value does not contradict the limit.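

In this assay compound 4 gives > 21500 nM, a limit of the assay and not a number. No new step can be read between compound 4 and compound 1, compound 2 or compound 3, as every value rests on the same limit: the limit of > 21500 nM in this assay, at which 4 of the 4 values shown sit. The compounds shown leave open whether any of these four differs from the others in this read-out.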